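A few compounds are considered here, and "the series" means these few. Any claim that something is new, unique, unknown or untested is made for them only; others in the source may bear on it.

The measured compounds are these:

Compound 1, `COc1ccc2cc(C(C)c3nnc4n3N=C(c3ccc(Br)cc3)CS4)ccc2c1`, which in a functional assay on HCT-116 cells (Homo sapiens) for inhibition, read by sulforhodamine B assay, with a stated time of 72 h (a lower number here means a stronger inhibitor, a higher number a weaker inhibitor), gives 11700 nM.
Compound 2, `COc1ccc2cc(C(C)c3nnc4n3N=C(c3ccc(F)cc3)CS4)ccc2c1`, which in this assay gives 13100 nM.
Compound 3, `CC(c1ccc(-c2ccccc2)c(F)c1)c1nnc2n1N=C(c1ccc(Br)cc1)CS2`, which in this assay gives 7100 nM.

Compounds 1 and 2 share one core and differ in a single spot: fluoro in place of bromo on an aromatic carbon. That change gave a 1.1-fold higher number from compound 1 to compound 2 (0.05 log units; within the scatter), so the two numbers sit within the scatter of each other and no order between them can be read.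

Compound 3 carries a different core; the difference between the two cores is not broken down here. Its number in this assay lies within the scatter of both compound 1 and compound 2, so none of the three can be called the stronger.

Compound 4, `CC(c1ccc(-c2ccccc2)c(F)c1)c1nnc2n1N=C(c1ccc(F)cc1)CS2`, is not yet measured. It differs from compound 3 by fluoro in place of bromo on an aromatic carbon. This is the same change that separates compound 2 from compound 1, made on the other core, at a place described in the same words.

Because the same change gave a 1.1-fold higher number from compound 1 to compound 2 (0.05 log units; within the scatter), compound 4 is expected to stay close to compound 3, the expected step being a 1.1-fold higher number from compound 3 to compound 4 (0.05 log units; within the scatter). Going by the values given here, the second core gives no measured step of this kind, so the expectation rests only on that one pair. Compound 4 is therefore estimated at 7900 nM in this assay, with a range from 4000 nM to 16000 nM.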

Compound 4, half-maximal inhibitory concentration: 10500 nM
Compound 4: middle estimate off by 1.3-fold (0.12 log units), on the low side; low and high end bracket the measured number.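

In this assay, fluoro in place of bromo on the second core gave a 1.5-fold higher number from compound 3 to compound 4 (0.17 log units; within the scatter), so the two numbers cannot be put in order. Set beside the same change on the first core, the two steps do not differ in any way that can be read: the same change on two cores in this assay, a 1.1-fold higher number (0.05 log units; within the scatter) from compound 1 to compound 2 and a 1.5-fold higher number (0.17 log units; within the scatter) from compound 3 to compound 4, 1.3-fold (0.12 log units) apart, within the scatter of two such steps

This shows that, in this assay, the exchange of 4-bromophenyl for 4-fluorophenyl carried over from one core to the other without a readable change in either pair, and that the core made no visible difference to the size of the step. Going by these compounds alone, it does not show that the two halogens are interchangeable in general, as it rests on only two pairs and one cell-based read-out, and two steps that are both within the scatter cannot reveal a small shared effect or a small dependence on the core.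

The compounds shown leave open what a group other than a halogen, such as methoxy, an amine or a carboxylic acid, would do at this place on the ring. They also leave open whether a step of a larger size, should one appear with such a group, would carry from one core to the other as closely as this one.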